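Trading 2,4-difluorophenyl for phenyl

This account rests on a few compounds, and the source may have more. Where it says the series, first, only, none or still open, it means among the compounds named here.

In a functional assay on MCF7 cells (Homo sapiens) for cytotoxicity, read by MTT assay, with a stated time of 72 h (a lower number here means a stronger inhibitor, a higher number a weaker inhibitor), compound 1 `O=C1C(=Cc2cccc(Cl)c2)C(=O)N(c2ccc(Cl)cc2)N1c1ccc(Cl)cc1` gives 18300 nM and compound 2 `O=C1C(=Cc2ccc(F)cc2F)C(=O)N(c2ccc(Cl)cc2)N1c1ccc(Cl)cc1` gives 22000 nM, so the two stand level within the usual scatter. Compound 3 `O=C1C(=Cc2ccccc2)C(=O)N(c2ccc(Cl)cc2)N1c1ccc(Cl)cc1` carries phenyl in place of 2,4-difluorophenyl on a double-bonded chain carbon bound to a double-bonded ring carbon. Within the data shown here, only one measured step changes this same place, a 1.2-fold higher number from compound 1 to compound 2 (0.08 log units; within the scatter), and it stayed within the scatter. No step beyond the scatter is therefore expected in this assay, though one step is thin evidence. The expected step is a 1.1-fold lower number from compound 2 to compound 3 (0.04 log units; within the scatter). Compound 3 is estimated at 20000 nM, with an expected range of 9000 nM to 42000 nM.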

Compound 3, half-maximal inhibitory concentration: 20200 nM
Compound 3: middle estimate off by 1.0-fold (0.00 log units), on the low side; low and high end bracket the measured number.
By their numbers in this assay, from the lowest: compounds 1, 3 and 2 (each within the scatter of the next).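

Plain phenyl gives this position a reference point: in this assay, the two fluoro groups are exchanged for hydrogens in a 1.1-fold lower number from compound 2 to compound 3 (0.04 log units; within the scatter), and the chloro is exchanged for hydrogen in a 1.1-fold higher number from compound 1 to compound 3 (0.04 log units; within the scatter). Both steps lie within the scatter, so neither the chloro of compound 1 nor the two fluoro groups of compound 2 can be told apart from no halogen at all on this ring. Nothing measured here speaks to why the three compounds stand level.

The compounds shown leave open whether an amine or a carboxylic acid on this phenyl, or a longer chain in its place, would give a step beyond the scatter.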